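This account rests on a few compounds, and the source may have more. Where it says the series, first, only, none or still open, it means among the compounds named here.

Compounds measured in a functional assay on the whole organism with Mus musculus as the target, in the maximal electroshock model, with a stated time of 0.5 h; on this read-out lower numbers stand for an effect already at smaller amounts and higher numbers for an effect only at larger amounts of compound:
- compound 1, `O=C(N/N=C/c1ccccc1Cl)Nc1ccc(Br)cc1`: 300 mg/kg
- compound 2, `O=C(N/N=C/c1ccccc1[N+](=O)[O-])Nc1ccc(Br)cc1`: 300 mg/kg
- compound 3, `O=c1snc(Nc2ccccn2)n1-c1ccccn1`: 300 mg/kg

Compound 1 stands level with compounds 2 and 3 on these numbers; none of the three is set apart from the others. Within the data shown here, the one measured step, nitro in place of chloro on an aromatic carbon, gives no change at the digits printed from compound 1 to compound 2 (within the scatter) in this assay.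

Compound 4, `CCOc1ccc(NC(=O)N/N=C/c2ccccc2Cl)cc1`, differs from compound 1 by ethoxy in place of bromo on an aromatic carbon. Among the measured compounds shown here, no measured step touches the bromo position, so the only guidance is that the one recorded change left the dose unmoved. A step of about no change at the digits printed from compound 1 to compound 4 (within the scatter) is therefore expected, none beyond the scatter. Compound 4 is estimated at 300 mg/kg, within 100 mg/kg to 600 mg/kg.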

Compound 4, minimum effective dose: 100 mg/kg
The estimate for compound 4 lay 3.0-fold (0.48 log units) above the measured number; the measured number falls inside the stated range.
By their numbers in this assay, from the lowest: compound 4; then compounds 1, 2 and 3 (each within the scatter of the next).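

In this assay, ethoxy in place of bromo on the aromatic carbon gives a 3.0-fold lower number from compound 1 to compound 4 (0.48 log units; beyond the scatter), a modest step. Among these compounds, the earlier compounds showed no step beyond the scatter, so this is the first sign that the dose responds to a change on the shared core, and that it responds at this position. No available evidence accounts for the shift. As far as these compounds go, whether methoxy, a longer alkoxy chain or an amine at this position would do the same remains open. So does whether the step holds with nitro in place of chloro.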